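The source may hold more compounds than are shown below. What is called first, only, known or untested is meant among the compounds shown, and "the series" means these compounds.

Measured compounds:
Compound 1: `Nc1ncnc2c1ncn2[C@H]1C=C(Br)[C@H](CO)[C@H]1CO` — > 100000 nM
Compound 2: `Nc1ncnc2c1ncn2[C@H]1C=C(Cl)[C@H](CO)[C@H]1CO` — "not determined" (no result reported)
Compound 3: `Nc1ncnc2c1ncn2[C@H]1C=C(F)[C@H](CO)[C@H]1CO` — not yet measured

In an ADME assay on HepG2 2.2.15 cells (Homo sapiens) for cytotoxicity, read by MTT assay, with a stated time of 7 days (on this read-out higher numbers stand for lower toxicity in this test and lower numbers for higher toxicity in this test), compound 1 gives > 100000 nM. That value is a limit of the assay and not a number. Compound 2 gives "not determined" (no result reported) in this assay, so no result exists for it at all. On the numbers shown, compound 2 therefore stands nowhere; the only other figure in the set is the limit of > 100000 nM in this assay, at which 1 of the 2 values shown sits, which is itself a limit rather than a measured number.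

The step from compound 2 to compound 3 changes a single atom on the shared core: fluoro in place of chloro on a double-bonded ring carbon. The rest of the molecule is unchanged.

Going by the values given here, no step between two measured compounds exists in this set, so no measured size of step can be read off for this assay. The expectation is for no shift beyond the usual scatter, in either direction. Among the compounds with values here, the only anchor is compound 1 at > 100000 nM, a limit at the top of the range. Compound 3 is expected to give about 100000 nM, estimated to lie between 30000 nM and 300000 nM.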

Compound 3, half-maximal cytotoxic concentration: > 100000 nM
Compound 3: only a limit was reported; the forecaster's own chance of this, stated with the estimate: 70%; the middle value lies on the limit itself.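

No step from compound 1 to compound 3 can be read in this assay, because each gives only a limit and not a number: the limit of > 100000 nM in this assay, at which 2 of the 3 values shown sit.

The compounds shown leave open whether fluoro in place of bromo on the double-bonded ring carbon changes toxicity in this assay at all.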